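Swapping the ester end group in an anilide series

The compounds below may be only part of what the source reports. "The series", "measured", "known", "first", "only" and "open" are said of these compounds alone.

Measured so far:
compound 1 `CCOC(=O)/C=C/c1ccc(NC(=O)C2(NC(=O)c3ccc4c(C5CCCC5)c(-c5ncc(Cl)cn5)n(C)c4c3)CCC2)cc1OCC`: 3.07 h
compound 2 `CCOc1cc(NC(=O)C2(NC(=O)c3ccc4c(C5CCCC5)c(-c5ncc(Cl)cn5)n(C)c4c3)CCC2)ccc1/C=C/C(=O)OCc1ccccc1`: 2.17 h

Two compounds share one core and differ only at the far end of their ester. In an ADME assay (liver) for pharmacokinetics, with Liver microsome (Rattus norvegicus) as the target, using microsomes (a lower number here means that the compound disappears faster, a higher number that the compound lasts longer), compound 1 gives 3.07 h, and in this assay compound 2 gives 2.17 h. Compound 2 holds the lowest of these two numbers, yet the step of a 1.4-fold lower number from compound 1 to compound 2 (0.15 log units; within the scatter) is within the scatter, so the two cannot be told apart. Compound 3 `CCCN(C)C(=O)COC(=O)/C=C/c1ccc(NC(=O)C2(NC(=O)c3ccc4c(C5CCCC5)c(-c5ncc(Cl)cn5)n(C)c4c3)CCC2)cc1OCC` has not yet been measured. It differs from compound 2 in one place: methyl(propyl)carbamoyl in place of phenyl on a saturated chain carbon bound to an oxygen next to a carbonyl group. Among the compounds with values here, no measured step introduces such a group; the only known step, a 1.4-fold lower number from compound 1 to compound 2 (0.15 log units; within the scatter), altered the same place and stayed within the scatter. On that footing compound 3 is expected to show only a step of a 1.0-fold higher number from compound 2 to compound 3 (0.01 log units; within the scatter), not beyond the scatter. The estimate for compound 3 is 2.2 h, with a range from 1 h to 4.5 h.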

Compound 3, half-life: 0.317 h
Beside the measured number, compound 3's estimate is 6.9-fold (0.84 log units) above it; the whole stated range lies above it.
By their numbers in this assay, from the lowest: compound 3; then compounds 2 and 1 (each within the scatter of the next).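

The far end of this ester is not a silent place in this assay: replacing methyl with phenyl stayed within the scatter, but methyl(propyl)carbamoyl gives a 6.8-fold lower number from compound 2 to compound 3 (0.84 log units; beyond the scatter) and a 9.7-fold lower number from compound 1 to compound 3 (0.99 log units; beyond the scatter). So a change on this saturated chain carbon bound to an oxygen next to a carbonyl group can shorten the half-life, and among the three end groups shown, only methyl(propyl)carbamoyl separates from the others. Nothing measured here explains why the half-life falls.

The compounds shown leave open which part of methyl(propyl)carbamoyl carries the step, the carbonyl or the propyl chain. They also leave open whether a plain amine, a carboxylic acid or a carbamoyl with a longer chain at this place would behave the same way.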